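Methoxy for Methyl: Expecting Little Change in Compound 4

The source may hold more compounds than are shown below. What is called first, only, known or untested is meant among the compounds shown, and "the series" means these compounds.

Of the compounds shown here, three have been measured in an assay on cells for inhibition of Amine oxidase [flavin-containing] B (Homo sapiens), read by fluorescence and Amplex Red, using microsomes, with a stated time of 15 min; a higher number here means a weaker inhibitor, a lower number a stronger inhibitor. Compound 1 `Cc1ccc(NC(=O)c2coc3ccc(C)cc3c2=O)cc1` gives 152 nM, compound 2 `Cc1ccc2oc(=O)c(C(=O)Nc3ccc(Cl)cc3)cc2c1` gives 11.1 nM, and compound 3 `Cc1ccc2occ(C(=O)Nc3ccc(Cl)cc3)c(=O)c2c1` gives 45.4 nM. On these numbers compound 3 stands second highest of the three, with compound 1 nearest to it and compound 2 furthest from it. Among the compounds with values here, the only step between measured compounds that differ in one place is a 3.3-fold lower number from compound 1 to compound 3 (0.52 log units; beyond the scatter), a modest change; compound 2 and compound 3 differ in the arrangement of the shared core rather than in a single group, so no step is given for that pair.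

Compound 4 `COc1ccc2occ(C(=O)Nc3ccc(Cl)cc3)c(=O)c2c1` differs from compound 3 by methoxy in place of methyl on an aromatic carbon. Within the data shown here, no measured step bears on this kind of exchange, since the one step on record concerns a different group at a different place, and it therefore gives no guidance on direction. The expectation is a step that stays within the usual scatter, a 1.0-fold lower number from compound 3 to compound 4 (0.00 log units; within the scatter). Compound 4 is estimated at 45 nM in this assay, with a range from 15 nM to 140 nM.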

Compound 4, half-maximal inhibitory concentration: 10.3 nM
Compound 4: middle estimate off by 4.4-fold (0.64 log units), on the high side; measured number below the stated range.
By their numbers in this assay, from the lowest: compounds 4 and 2 (each within the scatter of the next); then compound 3; then compound 1.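

In this assay, within the data shown here, methoxy in place of methyl on this aromatic carbon gives a 4.4-fold lower number from compound 3 to compound 4 (0.64 log units; beyond the scatter) and so shows that this position responds to change, which the earlier compounds could not show, as all of them carry methyl on this ring. Methoxy brings one more heavy atom, an oxygen counted as a hydrogen-bond acceptor, but this single step cannot tell which feature of the exchange goes with the lower number. Nothing measured here offers a reason for the step.

On these data alone, whether a hydroxyl, an ethoxy or an amine at this place would give a still lower number or a higher one remains open. Also open, as far as these compounds go, is whether methoxy would produce a similar step on the core of compound 2.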